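Changing the aryl ester of a limit-bound sulfonate

This account rests on a few compounds, and the source may have more. Where it says the series, first, only, none or still open, it means among the compounds named here.

The compound pair under study shares a core seen in compound 1 `Cc1ccccc1OS(=O)(=O)c1ccc(N2CCN(C)C2=O)cc1` and compound 2 `CCCN1CCN(c2ccc(S(=O)(=O)Oc3ccccc3C)cc2)C1=O`. In a functional assay on MCF7 cells (Homo sapiens) for antiproliferative activity, read by sulforhodamine B assay, with a stated time of 48 h (a lower number here means a stronger inhibitor, a higher number a weaker inhibitor), compound 1 gives 5600 nM. Compound 2 reaches only the limit of the assay, > 100000 nM, so no number is known for it. Within the data shown here, the step of an at least 17-fold higher number from compound 1 to compound 2 (1.25 log units; beyond the scatter) is the only measured step, and it concerns the chain rather than the aryl ester. Compound 3 `CCCN1CCN(c2ccc(S(=O)(=O)Oc3cc(OC)cc(OC)c3)cc2)C1=O` carries the same chain as compound 2. In this assay, among the measured compounds shown here, compound 3 gives 270 nM; no step between compound 2 and compound 3 is computed, so their two values stand side by side without more. Compound 4 `CCCN1CCN(c2ccc(S(=O)(=O)Oc3ccc(F)cc3)cc2)C1=O` differs from compound 2 at the aryl ester: 4-fluorophenyl in place of 2-methylphenyl on an oxygen. For the measured compounds named here, no measured step bears on this change, and compound 2 itself sits at the limit of > 100000 nM in this assay, at which 1 of the 3 values shown sits. With compound 3 showing that the aryl ester can carry a numeric value, compound 4 is expected to move an at least 3.3-fold lower number from compound 2 to compound 4 (0.52 log units; beyond the scatter), to an estimated 30000 nM with a range from 3000 nM to 100000 nM.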

Compound 4, half-maximal inhibitory concentration: 33000 nM
For compound 4 the middle estimate is 1.1-fold (0.04 log units) below the measured one; measured number inside the range.
By their numbers in this assay, from the lowest: compound 3; then compound 1; then compound 4. At a limit, above all of these: compound 2.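

Among these compounds, the first step at the aryl ester is an at least 3.0-fold lower number from compound 2 to compound 4 (0.48 log units; beyond the scatter), and the chain stays fixed across it. In this assay compound 4 gives 33000 nM, so 4-fluorophenyl on this oxygen yields a number with the chain of compound 2, as the aryl ester of compound 3 also does. Going by these compounds, compound 2 stands at a limit and not at a number, so the true size of the step stays unknown and only its lower bound can be read: the limit of > 100000 nM in this assay, at which 1 of the 4 values shown sits.

The compounds shown leave open whether the step belongs to the arrival of the fluorine or to the loss of the methyl. Also open, on these data alone, are how an unsubstituted phenyl, or a phenyl bearing an amine or a carboxylic acid, would read on this oxygen, and whether 4-fluorophenyl would act alike with the chain of compound 1.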